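Working notes on compound 3 and the proposed compound 4

The source may report more compounds than this note shows. Statements on the series, on what has been measured and on what is new or still open speak of the compounds shown alone.

Measured so far:
compound 1, `O=C(Nc1cccc(-n2cc(-c3ccncc3)c(-c3ccc(Cl)c(O)c3)n2)c1)Nc1cccc(C(F)(F)F)c1`, 3540 nM
compound 2, `COc1cc(-c2nn(-c3cccc(NC(=O)Nc4cc(C(F)(F)F)cc(C(F)(F)F)c4)c3)cc2-c2ccncc2)ccc1Cl`, 829 nM
compound 3, `COc1cc(-c2nn(-c3cccc(NC(=O)Nc4cccc(C(F)(F)F)c4)c3)cc2-c2ccncc2)ccc1Cl`, 890 nM

All three numbers come from a functional assay on SF-539 cells (Homo sapiens) for inhibition, read by sulforhodamine B assay, with a stated time of 48 h; a lower number here means a stronger inhibitor of growth, a higher number a weaker inhibitor of growth. Compound 3 stands second highest of the three; its nearest neighbour is compound 2, which differs by a 1.1-fold higher number from compound 2 to compound 3 (0.03 log units; within the scatter), a gap within the scatter, while compound 1 lies furthest, with a 4.0-fold lower number from compound 1 to compound 3 (0.60 log units; beyond the scatter) separating the two.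

Compound 4, `COc1cc(-c2nn(-c3cccc(NC(=O)c4ccccc4)c3)cc2-c2ccncc2)ccc1Cl`, has not been measured. It differs from compound 3 in one place: phenyl in place of (3-(trifluoromethyl)phenyl)amino on a carbonyl carbon. Neither measured step bears directly on this change. The step from compound 1 to compound 3 concerns a methyl on an oxygen elsewhere in the molecule, and the step from compound 2 to compound 3 only removes a trifluoromethyl from the same aromatic ring that is now lost altogether. Nothing in the series shows what happens when the amino part, with its hydrogen-bond donor, is taken out of the carbonyl linker. A modest loss is therefore assumed rather than inferred, and the range is kept wide.

Compound 4 is expected to give 2500 nM in this assay, between 800 nM and 8000 nM, corresponding to an estimated step of a 2.8-fold higher number from compound 3 to compound 4 (0.45 log units; beyond the scatter).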

Compound 4, concentration for 50% growth inhibition: 387 nM
Compound 4: the middle estimate sits 6.5-fold (0.81 log units) above what was measured, outside the stated range (below it).
By their numbers in this assay, from the lowest: compound 4; then compounds 2 and 3 (each within the scatter of the next); then compound 1.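

In this assay, phenyl in place of (3-(trifluoromethyl)phenyl)amino on the carbonyl carbon gives a 2.3-fold lower number from compound 3 to compound 4 (0.36 log units; beyond the scatter), so in this pair the substituent on the carbonyl carbon can be shortened and its amino nitrogen, with its hydrogen-bond donor, removed without any loss of growth inhibition. The earlier compounds shown here showed only that removing one trifluoromethyl from this terminal ring left the number within the scatter, as a 1.1-fold higher number from compound 2 to compound 3 (0.03 log units; within the scatter) records; this result shows that the position responds to a larger change and that the amino link is not required for activity in compound 4. No measurement here accounts for the gain, so its cause remains unassigned.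

The amino nitrogen and the trifluoromethyl leave in the same step, and the compounds shown do not separate their contributions; plain phenylamino or 3-(trifluoromethyl)phenyl on the carbonyl carbon would pull the two apart. Going by these compounds, how far the position tolerates a departure from an aromatic ring is also open, for example with cyclohexyl or a short alkyl chain such as ethyl on the carbonyl carbon.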